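A few compounds are considered here, and "the series" means these few. Any claim that something is new, unique, unknown or untested is made for them only; others in the source may bear on it.

Of the compounds shown here, two have been measured in a functional assay on MCF7 cells (Homo sapiens) for cytotoxicity, read by CellTiter-Glo, with a stated time of 5 days; a higher number here means a weaker inhibitor, a lower number a stronger inhibitor. Compound 1 `CCCC/C(=C(/c1ccc(/C=C/C(=O)O)cc1)c1ccc2[nH]ncc2c1)c1ccccc1` gives 10 nM in this assay. Compound 2 `CC/C(=C(/c1ccc(/C=C/C(=O)O)cc1)c1cc2cn[nH]c2cn1)c1ccccc1` gives 442 nM in this assay, the higher of the two numbers, and the gap to compound 1 lies beyond the usual scatter. Compound 3 `CC/C(=C(/c1ccc(/C=C/C(=O)O)cc1)c1ccc2[nH]nc(F)c2c1)c1ccccc1` differs from compound 2 in one place: a group of 10 heavy atoms (7 carbon, 2 nitrogen, 1 fluorine; one five-membered aromatic ring with 2 hetero atoms, one six-membered aromatic ring of carbon only) in place of a group of 9 heavy atoms (6 carbon, 3 nitrogen; one five-membered aromatic ring with 2 hetero atoms, one six-membered aromatic ring with 1 hetero atom), on a double-bonded chain carbon bound to an aromatic carbon and a double-bonded chain carbon. Within the data shown here, the entering group resembles the one carried by compound 1, which gave 10 nM, so a drop in the number seems likely. The expected step is a 9.8-fold lower number from compound 2 to compound 3 (0.99 log units; beyond the scatter) in this assay. Compound 3 is estimated at 45 nM, within 10 nM to 200 nM.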

Compound 3, half-maximal inhibitory concentration: 5 nM
For compound 3 the middle estimate is 9.0-fold (0.95 log units) above the measured one; measured number below the stated range.
By their numbers in this assay, from the lowest: compounds 3 and 1 (each within the scatter of the next); then compound 2.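

Among these compounds, the step of an 88-fold lower number from compound 2 to compound 3 (1.95 log units; beyond the scatter) in this assay is the first comparison that isolates this position, on a double-bonded chain carbon, and it shows that the attached group strongly affects the number. Both groups contain a five-membered aromatic ring with 2 hetero atoms, so that shared ring alone does not settle the result. No measurement here explains the step.

Going by these compounds, the change replaces the six-membered ring and adds fluorine together, so their separate contributions remain open. Also open, on these data alone, is how a chlorine or nitrile in place of the fluorine would read.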